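The source may hold more compounds than are shown below. What is called first, only, known or untested is meant among the compounds shown, and "the series" means these compounds.

The measured compounds:
Compound 1 `Fc1ccc2nc(-c3ccccc3)nc(Nc3ccccc3)c2c1` in a functional assay on COLO 205 cells (Homo sapiens) for cytotoxicity, read by MTT assay, with a stated time of 48 h (on this read-out higher numbers stand for weaker inhibition and lower numbers for stronger inhibition), gives > 50000 nM, which is a limit of the assay and not a number.
Compound 2 `Fc1cccc(-c2nc(Nc3ccc(Br)cc3)c3cc(F)ccc3n2)c1` gives > 50000 nM, also only a limit.
Compound 3 `Oc1cccc(Nc2nc(-c3cccc(F)c3)nc3ccc(F)cc23)c1` gives > 50000 nM, again a limit.

Compound 2 therefore has no number of its own; it sits at the limit of > 50000 nM in this assay, at which 3 of the 3 values shown sit, together with the other two, and no order among them can be read. Compound 4 `Cc1ccc(Nc2nc(-c3cccc(F)c3)nc3ccc(F)cc23)cc1` differs from compound 2 by methyl in place of bromo on an aromatic carbon. For the measured compounds named here, the only measured step that touches this position, a step that the two limits leave unreadable from compound 2 to compound 3, gives no readable size, so no measured change bears on the methyl for bromo exchange. With every value at the limit of > 50000 nM in this assay, at which 3 of the 3 values shown sit, no step beyond the scatter can be expected in either direction. Compound 4 is expected to give about 60000 nM, within 15000 nM to 250000 nM. This expectation amounts to an estimated step that the limit leaves unreadable from compound 2 to compound 4.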

Compound 4, half-maximal inhibitory concentration: > 50000 nM
Compound 4: a limit, no number (the forecaster's own chance of this, stated with the estimate: 80%); the middle value is on the limit's open side.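

No size can be read for the steps joining compound 4 to compound 2 and compound 3, because each value is only a limit: the limit of > 50000 nM in this assay, at which 4 of the 4 values shown sit.

As far as these compounds go, whether any change to the shared core gives a readable number in this assay stays open.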